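This account rests on a few compounds, and the source may have more. Where it says the series, first, only, none or still open, it means among the compounds named here.

In a functional assay (KB-V1/Vbl cells, Homo sapiens) for inhibition, read by MTT assay, with a stated time of 72 h (on this read-out higher numbers stand for weaker inhibition and lower numbers for stronger inhibition), compound 1 `COc1cc(/C=C/C(=O)c2ccc3ccccc3c2)cc(Br)c1OC` gives 10500 nM, and compound 2 `COc1cc(/C=C/C(=O)c2ccc3ccccc3c2)cc(I)c1OC` gives 16500 nM. Among the compounds with values here, with only these two numbers available, compound 2 stands within the scatter of compound 1, its sole measured neighbour. Compound 3 `COc1cc(/C=C/C(=O)c2ccc3ccccc3c2)cc(OC)c1OC` has yet to be measured in this assay. Relative to compound 2, it carries methoxy in place of iodo on an aromatic carbon. Within the data shown here, one measured step bears on this change, the exchange of bromo for iodo at the same place, which amounts to a 1.6-fold higher number from compound 1 to compound 2 (0.20 log units; within the scatter). Among the measured compounds shown here, no measured step shows methoxy entering there, so the evidence is thin. No step beyond the scatter is therefore expected in this assay. The estimated change is a 1.5-fold lower number from compound 2 to compound 3 (0.18 log units; within the scatter). Compound 3 is expected at 11000 nM, with an estimated range from 3500 nM to 30000 nM.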

Compound 3, half-maximal inhibitory concentration: 13900 nM
Estimate against measurement, compound 3: 1.3-fold (0.10 log units) below, within the range that was stated.
By their numbers in this assay, from the lowest: compounds 1, 3 and 2 (each within the scatter of the next).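

In this assay, methoxy in place of iodo gives a 1.2-fold lower number from compound 2 to compound 3 (0.07 log units; within the scatter) and methoxy in place of bromo gives a 1.3-fold higher number from compound 1 to compound 3 (0.12 log units; within the scatter) and so both steps lie within the scatter. This position, on an aromatic carbon ortho to a methoxy group, therefore accepts a group of two heavy atoms carrying a hydrogen-bond acceptor as well as either halogen, and this read-out does not separate the three compounds. Nothing available accounts for this similarity.

As far as these compounds go, whether the position stays this undemanding with an amine, a carboxylic acid or a longer chain such as butoxy remains open. The compounds shown also leave open whether a plain hydrogen or a fluoro group here would fall within the same scatter, and whether the result holds on a different core.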